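Swapping the thiophene of compound 3

The source may hold more compounds than are shown below. What is called first, only, known or untested is meant among the compounds shown, and "the series" means these compounds.

Measured in a functional assay on HT-29 cells (Homo sapiens) for antiproliferative activity, read by MTT assay, with a stated time of 72 h (a higher number here means a weaker inhibitor, a lower number a stronger inhibitor), so far:
- Compound 1 `C=C(Br)C(=O)Nc1ccc2c(c1)/C(=C/c1cccs1)C(=O)N2` gives 240 nM
- Compound 2 `C=C(Br)C(=O)Nc1ccc2c(c1)/C(=C\c1sccc1C)C(=O)N2` gives 330 nM
- Compound 3 `C=C(Br)C(=O)Nc1ccc2c(c1)/C(=C/c1ccsc1)C(=O)N2` gives 600 nM

Compound 3 has the highest number of the three, but only its gap to compound 1 lies beyond the scatter. Compound 4 `C=C(Br)C(=O)Nc1ccc2c(c1)/C(=C/c1sccc1C)C(=O)N2` has 3-methylthiophen-2-yl in place of thiophen-3-yl (3-methylthiophen-2-yl in place of thiophen-3-yl on a double-bonded chain carbon bound to a double-bonded ring carbon). The closest evidence is a 2.5-fold higher number from compound 1 to compound 3 (0.40 log units; beyond the scatter), a modest step that, read backwards, suggests a lower number for a thiophen-2-yl group. Compound 2 carries the same 3-methylthiophen-2-yl group, with the opposite arrangement at the double bond, and gives 330 nM. Going by the values given here, no measured step isolates the methyl group, so a modest fall is expected in this assay. The expected change is a 1.9-fold lower number from compound 3 to compound 4 (0.27 log units; within the scatter). Compound 4 is estimated at 320 nM, with an expected range of 140 nM to 700 nM.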

Compound 4, half-maximal inhibitory concentration: 1200 nM
For compound 4 the middle estimate is 3.8-fold (0.57 log units) below the measured one; the whole stated range lies below it.
By their numbers in this assay, from the lowest: compounds 1, 2, 3 and 4 (each within the scatter of the next, the first and the last beyond it).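

The arrangement at the double bond alone shifts the number, with a 3.6-fold higher number from compound 2 to compound 4 (0.56 log units; beyond the scatter) in this assay, and the step can be read that way for one reason: the fact that compounds 2 and 4 differ only in the configuration as drawn. The methyl group is now isolated too, with a 5.0-fold higher number from compound 1 to compound 4 (0.70 log units; beyond the scatter). The swap of groups itself gives a 2.0-fold higher number from compound 3 to compound 4 (0.30 log units; within the scatter), which cannot be told apart from repeat variation.

Going by these compounds, whether methyl has a similar effect with the opposite arrangement at the double bond stays open. So does how an ethyl group or an amine in place of methyl would behave.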